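Methoxy Added to the Phenyl on the Shared Core

The source may hold more compounds than are shown below. What is called first, only, known or untested is meant among the compounds shown, and "the series" means these compounds.

Among the compounds with values here, compound 1 `COc1cc(/C=C/C(=O)c2cccc(-n3cc(-c4ccccc4)[nH]c3=O)c2)ccc1O` holds the highest of the two numbers measured so far: in a functional assay on OVCAR-8 cells (Homo sapiens) for inhibition (on this read-out lower numbers stand for stronger inhibition of growth and higher numbers for weaker inhibition of growth), compound 1 gives 4110 nM, and compound 2 `O=C(/C=C/c1cccc(O)c1)c1cccc(-n2cc(-c3ccccc3)[nH]c2=O)c1` gives 2800 nM. Within the data shown here, the only measured step, a 1.5-fold lower number from compound 1 to compound 2 (0.17 log units; within the scatter), replaces the aryl group on the chain and stays within the scatter, so the two values show no difference that can be read.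

Compound 3 `COc1ccc(-c2cn(-c3cccc(C(=O)/C=C/c4ccc(O)c(OC)c4)c3)c(=O)[nH]2)cc1` changes compound 1 at a different site: methoxy in place of hydrogen on an aromatic carbon, para to a large group, so that phenyl becomes 4-methoxyphenyl. Among the measured compounds shown here, no measured step touches this ring, and the one step that exists concerns the other aryl group and was small. The account therefore expects no movement beyond the scatter, in either direction. Compound 3 is estimated at 4000 nM, with a range from 1500 nM to 11000 nM. The expected step is a 1.0-fold lower number from compound 1 to compound 3 (0.01 log units; within the scatter), and whether it holds awaits the measurement.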

Compound 3, concentration for 50% growth inhibition: 4970 nM
Beside the measured number, compound 3's estimate is 1.2-fold (0.09 log units) below it; measured number inside the range.
By their numbers in this assay, from the lowest: compounds 2, 1 and 3 (each within the scatter of the next).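

With this compound the phenyl on the shared core carries its first measured change. In this assay, methoxy in place of hydrogen on this aromatic carbon, para to a large group, gives a 1.2-fold higher number from compound 1 to compound 3 (0.08 log units; within the scatter), so turning phenyl into 4-methoxyphenyl produces no difference that can be read. Nothing else at hand bears on this result.

On these data alone, a single group says little about the position as a whole, so it remains open whether an amine, a carboxylic acid or a longer chain on the same carbon would move the number beyond the scatter. Also open, as far as these compounds go, is whether methoxy on another carbon of that ring would read any differently, and whether a change to this ring would read the same with the 3-hydroxyphenyl of compound 2 on the chain.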